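The compounds below may be only part of what the source reports. "The series", "measured", "known", "first", "only" and "open" are said of these compounds alone.

Compound 3 `OC[C@@H](O[C@H]1CCCN(Cc2cccc3nonc23)[C@H]1c1ccccc1)c1cc(Cl)cc(Cl)c1` stands lowest of the two numbers measured in an assay on isolated protein for activation of cGMP-dependent protein kinase 1 (Homo sapiens), read by ADP-Glo, with stated times of 120 min and 40 min (a higher number here means that more compound is needed for the effect, a lower number that less compound is needed), at 8000 nM. Within the data shown here, its nearest neighbour is compound 2 `O=C(O)c1cncc(CN2CCC[C@H](O[C@H](CO)c3cc(Cl)cc(Cl)c3)[C@@H]2c2ccccc2)c1`, which in this assay gives 34000 nM; the only measured step, a 4.3-fold lower number from compound 2 to compound 3 (0.63 log units; beyond the scatter), exchanges one aromatic side group for another on a saturated chain carbon bound to an amine nitrogen in a ring. Compound 1 `CN1CCC[C@H](OCc2cc(Cl)cc(Cl)c2)[C@@H]1c1ccccc1` reaches in this assay only a limit, > 200000 nM, as shown in the limit of > 200000 nM in this assay, at which 1 of the 3 values shown sits. Compound 4 `CN1CCC[C@H](O[C@H](CO)c2cc(Cl)cc(Cl)c2)[C@@H]1c1ccccc1` differs from compound 3 by a hydrogen atom in place of a group of 9 heavy atoms (6 carbon, 2 nitrogen, 1 oxygen; one five-membered aromatic ring with 3 hetero atoms, one six-membered aromatic ring of carbon only), on a saturated chain carbon bound to an amine nitrogen in a ring. Among the measured compounds shown here, no measured step removes this group entirely, so the measured step gives only an indirect guide: it shows that what sits on this carbon changes the number by a modest amount. Compound 1 and compound 4 carry the same small group on the ring nitrogen and differ elsewhere, and compound 1 gave only a limit. A step in the weaker direction is therefore expected from compound 3 to compound 4, roughly a 10-fold higher number from compound 3 to compound 4 (1.00 log units; beyond the scatter). Compound 4 is estimated at 80000 nM, within a range from 20000 nM to 300000 nM.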

Compound 4, half-maximal effective concentration: 42000 nM
Beside the measured number, compound 4's estimate is 1.9-fold (0.28 log units) above it; the measured number falls inside the stated range.
By their numbers in this assay, from the lowest: compound 3; then compounds 2 and 4 (each within the scatter of the next). At a limit, above all of these: compound 1.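

With the bare carbon now measured, this assay gives a direct reading of what the group in compound 3 contributes on a saturated chain carbon bound to an amine nitrogen in a ring: a 5.3-fold higher number from compound 3 to compound 4 (0.72 log units; beyond the scatter). The 5-carboxypyridin-3-yl group of compound 2 shows no such difference at the same place, a 1.2-fold higher number from compound 2 to compound 4 (0.09 log units; within the scatter), so the two aromatic groups are not interchangeable here. Hydroxymethyl in place of hydrogen also counts, with an at least 4.7-fold lower number from compound 1 to compound 4 (0.67 log units; beyond the scatter), and that size is only a floor, as compound 1 stands at a limit: the limit of > 200000 nM in this assay, at which 1 of the 4 values shown sits.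

A plain phenyl ring or an unsubstituted pyridine on this carbon would separate the effect of the carboxylic acid in compound 2 from that of its ring. Going by these compounds, whether a simple amine or a longer chain at this place would behave like either group remains open.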